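Isopropylsulfonyl in Place of Methyl on the Ring Amine

This account rests on a few compounds, and the source may have more. Where it says the series, first, only, none or still open, it means among the compounds named here.

Of the compounds shown here, three have so far been measured in an assay on HEK293 cells for negative allosteric modulation of metabotropic glutamate receptor 5 (Homo sapiens), read by FLIPR, with a stated time of 1 h; on this read-out higher numbers stand for weaker inhibition and lower numbers for stronger inhibition. Compound 1 `O=C1NCCc2nc(C#Cc3ccccc3F)sc21` gives > 10000 nM, which is a limit of the assay rather than a number. Compound 2 `Cc1cccc(C#Cc2nc3c(s2)C(=O)NCC3)c1` likewise gives > 10000 nM, again a limit. Compound 3 `CN1CCc2nc(C#Cc3ccccc3)sc2C1` also returns only a limit, > 10000 nM. Within the data shown here, compound 3 therefore stands at the limit of > 10000 nM in this assay, at which 3 of the 3 values shown sit, and nothing among the measured values separates it from the other two. Compound 4 `CC(C)S(=O)(=O)N1CCc2nc(C#Cc3ccccc3)sc2C1` differs from compound 3 by isopropylsulfonyl in place of methyl on an amine nitrogen in a ring. Among the measured compounds shown here, no measured step exists to guide this change. Compound 4 is expected to stay near the limit, with an expected step of an at least 1.1-fold lower number from compound 3 to compound 4 (0.04 log units; that floor lies within the scatter) not beyond the usual scatter. The estimate for compound 4 in this assay is 9000 nM, within 1500 nM to 30000 nM.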

Compound 4, half-maximal inhibitory concentration: 11 nM
Compound 4: middle estimate off by 820-fold (2.91 log units), on the high side; the whole stated range lies above it.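

In this assay, isopropylsulfonyl in place of methyl on the amine nitrogen in the ring gives an at least 900-fold lower number from compound 3 to compound 4 (2.95 log units; beyond the scatter), showing that the read-out responds strongly to a change at this position. Compound 4 is the only compound shown with a value that is not a limit: the limit of > 10000 nM in this assay, at which 3 of the 4 values shown sit.

The compounds shown do not separate the part played by the sulfonyl from that of the isopropyl. Going by these compounds, how methylsulfonyl, phenylsulfonyl or an acetyl group on the same nitrogen would read remains open.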